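Swapping the halogenated ring for a methylated one

The source may hold more compounds than are shown below. What is called first, only, known or untested is meant among the compounds shown, and "the series" means these compounds.

Measured compounds:
compound 1 `C=CCn1c(=O)/c(=C\c2cc(Br)ccc2F)[nH]c(=O)/c1=C\c1ccccc1OC` gives "not active" (no number reported) in a functional assay on NCI-H1975 cells (Homo sapiens) for cytotoxicity, read by CCK-8 assay, with a stated time of 72 h; on this read-out lower numbers stand for stronger inhibition and higher numbers for weaker inhibition
compound 2 `COc1ccccc1/C=c1\c(=O)[nH]/c(=C/c2cccc(Cl)c2Cl)c(=O)n1C` gives 300 nM in this assay

Compound 1 stands without a single number: it was reported only as inactive, so its place relative to compound 2 cannot be fixed. Compound 3 `C=CCn1c(=O)/c(=C\c2ccc(C)cc2)[nH]c(=O)/c1=C\c1ccccc1OC` carries 4-methylphenyl in place of 5-bromo-2-fluorophenyl on a double-bonded chain carbon bound to an aromatic carbon. For the measured compounds named here, since compound 1 has no number, no measured step can anchor this change; the expectation is that compound 3 moves toward weak activity, while staying well short of compound 2 and possibly again yielding no number. For compound 3 the estimated value in this assay is 5000 nM, with a range from 800 nM to 30000 nM.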

Compound 3, half-maximal inhibitory concentration: "not active" (no number reported)
Compound 3 has no reported number here; no gap can be computed for the estimate.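

Compound 1 and compound 3 were both reported as inactive without a number, so no step can be read between them. They leave open whether 5-bromo-2-fluorophenyl and 4-methylphenyl differ in their effect on activity. No further data bear on this result.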